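Pyridin-2-yl Replaces Dimethylaminomethyl on the Amide Chain

The source may hold more compounds than are shown below. What is called first, only, known or untested is meant among the compounds shown, and "the series" means these compounds.

Of the compounds shown here, three built on the shared core have been measured in a functional assay on CHO-RD-HGA16 cells for agonist activity at Orexin receptor type 2 (Homo sapiens), read by fluorescence and calcium flux, with a stated time of 30 min; on this read-out lower numbers stand for an effect already at smaller amounts and higher numbers for an effect only at larger amounts of compound. Compound 1 `COc1ccc(-c2cccc(C(=O)N(C)C)c2)cc1S(=O)(=O)Nc1cccc(N2CCN(C(=O)c3cccc(C)c3)CC2)c1` returns > 10000 nM, which is a limit of the assay and not a number. Compound 2 `COc1ccc(-c2cncc(C(=O)N(C)C)c2)cc1S(=O)(=O)Nc1cccc(NCCNC(=O)c2cccc(C)c2)c1` gives 619 nM. Compound 3 `COc1ccc(-c2cccc(C(=O)N(C)CCN(C)C)c2)cc1S(=O)(=O)Nc1cccc(NCCNC(=O)c2cccc(C)c2)c1` gives 293 nM, the lowest of the two numbers shown, and compound 2 sits higher by a gap that lies beyond the usual scatter of repeated measurements.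

Compound 4 `COc1ccc(-c2cccc(C(=O)N(C)Cc3ccccn3)c2)cc1S(=O)(=O)Nc1cccc(NCCNC(=O)c2cccc(C)c2)c1` has not been measured. It differs from compound 3 in one place: pyridin-2-yl in place of (dimethylamino)methyl on a saturated chain carbon bound to an amide-type nitrogen. Within the data shown here, no pair of measured compounds carries exactly this change, so the size and direction of the step cannot be read from the data; it has to be estimated. The expected step from compound 3 to compound 4 is a modest move toward larger amounts, a 1.7-fold higher number from compound 3 to compound 4 (0.23 log units; within the scatter). In this assay compound 4 is expected near 500 nM, with a likely range from 150 nM to 2000 nM.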

Compound 4, half-maximal effective concentration: 107 nM
Compound 4: middle estimate off by 4.7-fold (0.67 log units), on the high side; the measured number lies below the stated range.
By their numbers in this assay, from the lowest: compound 4; then compound 3; then compound 2. At a limit, above all of these: compound 1.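

At this place on the amide chain, the open-chain (dimethylamino)methyl is not required: in this assay, putting pyridin-2-yl in its place gives a 2.7-fold lower number from compound 3 to compound 4 (0.44 log units; beyond the scatter), a step beyond the usual scatter. Among these compounds, the earlier compounds carried no ring at this saturated chain carbon, so this is the first sign that a six-membered aromatic ring is accepted there, and that it goes with a lower number. No measurement shown bears on why the step runs in this direction.

Going by these compounds, it remains open whether the ring itself or its nitrogen matters, a question that phenyl or pyridin-3-yl at the same place could address. On these data alone, it is equally open how a longer chain carrying the pyridin-2-yl, or a carboxylic acid at this place, would read out.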